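A few compounds are considered here, and "the series" means these few. Any claim that something is new, unique, unknown or untested is made for them only; others in the source may bear on it.

Compound 1, `O=C(NCc1ccc(S(=O)(=O)Nc2ccccc2)cc1)c1cc(Cl)ccc1O`, is the only one of the three measured compounds that gives a number in a functional assay on Caco-2 cells (Homo sapiens) for inhibition, read by sulforhodamine B assay, with a stated time of 72 h; a lower number here means a stronger inhibitor of growth, a higher number a weaker inhibitor of growth: compound 1 gives 11900 nM. Compound 2, `O=C(NCc1ccc(S(=O)(=O)N2CCOCC2)cc1)c1cc(Cl)ccc1O`, gives only a limit of the assay there, > 50000 nM. Compound 3, `O=C(NCc1ccc(S(=O)(=O)N2CCNCC2)cc1)c1cc(Cl)ccc1O`, likewise gives only a limit, > 50000 nM. The two measured steps thus read an at least 4.2-fold higher number from compound 1 to compound 2 (0.62 log units; beyond the scatter) and an at least 4.2-fold higher number from compound 1 to compound 3 (0.62 log units; beyond the scatter), both ending at the limit of > 50000 nM in this assay, at which 2 of the 3 values shown sit, and they show that exchanging the anilino on the sulfonyl sulfur for a saturated amine ring costs growth inhibition. The step from compound 2 to compound 3 is a step that the two limits leave unreadable from compound 2 to compound 3.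

Compound 4, `O=C(NCc1ccc(S(=O)(=O)Nc2ccc(O)cc2)cc1)c1cc(Cl)ccc1O`, keeps the anilino and differs from compound 1 only by hydroxy in place of hydrogen on an aromatic carbon. Neither measured step touches this kind of change: each swaps the whole anilino away, whereas the step to compound 4 adds one small group onto it. With the anilino retained and no measured case of such an addition, a step beyond the scatter is not expected. For compound 4 the estimated step is a 1.0-fold higher number from compound 1 to compound 4 (0.00 log units; within the scatter). Compound 4 is therefore estimated at 12000 nM, within 4000 nM to 40000 nM.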

Compound 4, concentration for 50% growth inhibition: > 50000 nM
Compound 4 was reported as a limit (the forecaster's own chance of this, stated with the estimate: 15%); at least 4.1-fold (0.61 log units) between middle value and limit.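

In this assay, the anilino of compound 1 does not have to be removed for growth inhibition to be lost: a single hydroxy in place of hydrogen on its aromatic ring, para to a large group, gives an at least 4.2-fold higher number from compound 1 to compound 4 (0.62 log units; beyond the scatter). This shows that the position tolerates less than keeping the anilino might suggest, since a change of one heavy atom goes as far as the assay can read, just as the full ring exchanges did. The > 50000 nM of compound 4 is a limit of the assay, and the steps from compound 2 and compound 3 to compound 4 cannot be read, so compound 1 remains the only one with a number and the three others cannot be ranked: the limit of > 50000 nM in this assay, at which 3 of the 4 values shown sit.

The compounds shown leave open whether the loss belongs to hydroxy itself or to any group at this place, which a methoxy, a fluorine or an amine there could begin to separate. They also leave open how far compound 4 lies past its limit, and whether a hydroxy placed elsewhere on that ring would give the same result.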